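This account rests on a few compounds, and the source may have more. Where it says the series, first, only, none or still open, it means among the compounds named here.

Working notes on the series around compound 1, whose structure is `COC(=O)c1ccc(NC(=O)C2(C(=O)Nc3ccc(Nc4ncc5cc(C(=O)N(C)C)n(C6CCCC6)c5n4)cc3)CC2)cc1`. Within the data shown here, in a functional assay on A549 cells (Homo sapiens) for inhibition, read by CCK-8 assay, with a stated time of 72 h, tested at 1 uM (a higher number here means more inhibition of growth at the concentration tested, a lower number less inhibition of growth), compound 1 gives 77.1%, the highest of the three numbers measured so far. Compound 2, `CN(C)C(=O)c1cc2cnc(Nc3ccc(NC(=O)C4(C(=O)Nc5ccc(Cl)cc5)CC4)cc3)nc2n1C1CCCC1`, gives 24.7%, and compound 3, `CN(C)C(=O)c1cc2cnc(Nc3ccc(NC(=O)C4(C(=O)Nc5ccc(Cl)c(C(F)(F)F)c5)CC4)cc3)nc2n1C1CCCC1`, gives 1.1%. The step of a number 52.4 percentage points lower from compound 1 to compound 2 (beyond the scatter) is large, and the step of a number 76 percentage points lower from compound 1 to compound 3 (beyond the scatter) is larger still; the step of a number 23.6 percentage points lower from compound 2 to compound 3 (beyond the scatter) is modest.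

Compound 4, `CN(C)C(=O)c1cc2cnc(Nc3ccc(NC(=O)C4(C(=O)Nc5cccc(C#N)c5)CC4)cc3)nc2n1C1CCCC1`, has not yet been measured in this assay. Against compound 1 the change is 3-cyanophenyl in place of 4-(methoxycarbonyl)phenyl on an amide-type nitrogen. Among the measured compounds shown here, both measured steps away from compound 1 replace the same 4-(methoxycarbonyl)phenyl on the amide-type nitrogen and both lose much of the inhibition, so a sizeable loss is expected for compound 4 too, though the 3-cyanophenyl has no measured precedent here. The step of a number 47.1 percentage points lower from compound 1 to compound 4 (beyond the scatter) is the expected outcome. For compound 4 a value of 30% is estimated, with a range from 5% to 60%.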

Compound 4, percent growth inhibition at one concentration: 70.8%
The estimate for compound 4 lay 40.8 percentage points below the measured number; measured number outside the range, above it.
By their numbers in this assay, from the lowest: compound 3; then compound 2; then compounds 4 and 1 (each within the scatter of the next).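

In this assay, replacing the 4-(methoxycarbonyl)phenyl on the amide-type nitrogen need not cost inhibition: the 3-cyanophenyl gives a step that stays within the scatter (a number 6.3 percentage points lower from compound 1 to compound 4 (within the scatter)). The losses seen earlier therefore go with the 4-chloro-3-(trifluoromethyl)phenyl and 4-chlorophenyl groups in this series rather than with every replacement of the 4-(methoxycarbonyl)phenyl, as the steps to the 3-cyanophenyl show (a number 69.7 percentage points higher from compound 3 to compound 4 (beyond the scatter); a number 46.1 percentage points higher from compound 2 to compound 4 (beyond the scatter)). No supporting data are available to explain these differences.

What remains open is whether the nitrile or the methoxycarbonyl is needed at all, since a plain phenyl on this nitrogen does not appear among the compounds shown. On these data alone, how a phenyl carrying a carboxylic acid or an amine would read in this assay also remains open.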